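Working notes: from compound 2 to compound 3

A few compounds are considered here, and "the series" means these few. Any claim that something is new, unique, unknown or untested is made for them only; others in the source may bear on it.

- compound 1 `Cc1ccc(CN2CCc3ncn(COCc4ccccc4)c3/C(=C/c3ccccc3)C2=O)cc1`: 21200 nM
- compound 2 `Cc1cc(C)cc(CN2CCc3ncn(COCc4ccccc4)c3/C(=C/c3ccccc3)C2=O)c1`: 31300 nM

Both values come from a functional assay on A2780 cells (Homo sapiens) for inhibition, read by MTT assay, with a stated time of 72 h; on this read-out higher numbers stand for weaker inhibition and lower numbers for stronger inhibition. On these numbers compound 2 has a single neighbour, and the gap lies within the scatter: a 1.5-fold higher number from compound 1 to compound 2 (0.17 log units; within the scatter).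

The next structure is compound 3 `O=C1/C(=C\c2ccccc2)c2c(ncn2COCc2ccccc2)CCN1Cc1ccc(-c2ccccc2)cc1`. The change is 4-phenylphenyl in place of 3,5-dimethylphenyl on a saturated chain carbon bound to an amide-type nitrogen in a ring.

Among the compounds with values here, the one measured step bears on this change only through its place, since it alters the same group. Within the data shown here, it was small, and no measured step brings in 4-phenylphenyl, so the data set no direction. The expectation therefore rests on compound 2 at 31300 nM and stays close to it, with a wide margin for the untested group. The expected move is no larger than the scatter: a 1.4-fold lower number from compound 2 to compound 3 (0.15 log units; within the scatter). Compound 3 is estimated at 22000 nM, with an expected range of 8000 nM to 50000 nM.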

Compound 3, half-maximal inhibitory concentration: 48300 nM
For compound 3 the middle estimate is 2.2-fold (0.34 log units) below the measured one; the measured number falls inside the stated range.
By their numbers in this assay, from the lowest: compounds 1, 2 and 3 (each within the scatter of the next, the first and the last beyond it).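

In this assay, 4-phenylphenyl in place of 3,5-dimethylphenyl on a saturated chain carbon bound to an amide-type nitrogen in a ring brings in a second six-membered aromatic ring, yet the step stays within the scatter (a 1.5-fold higher number from compound 2 to compound 3 (0.19 log units; within the scatter)). Within the data shown here, the series now has its only step beyond the scatter, phenyl in place of methyl on an aromatic carbon (a 2.3-fold higher number from compound 1 to compound 3 (0.36 log units; beyond the scatter)), a modest step toward weaker inhibition, so across these three compounds the extra ring brings no stronger inhibition. No measurement at hand accounts for this step.

The compounds shown leave open whether an amine or a carboxylic acid on the aromatic ring at this position, or a longer chain to the amide-type nitrogen, would take the number out of the range spanned so far. They also say nothing about changes elsewhere, as the rest of the core of compound 1 stays the same in all three.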